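Dropping the methoxy group of compound 2

This account rests on a few compounds, and the source may have more. Where it says the series, first, only, none or still open, it means among the compounds named here.

Compound 1 `COc1ncc(-c2ccc3c(c2)N(c2ccccc2)C(=O)CO3)cc1NS(=O)(=O)c1ccc(F)cc1`: 1530 nM
Compound 2 `COc1cccc(N2C(=O)COc3ccc(-c4cccc(NS(=O)(=O)c5ccc(F)cc5)c4)cc32)c1`: > 40000 nM

In a functional assay on HeLa cells (Homo sapiens) for antiproliferative activity, read by MTT assay, with a stated time of 72 h (a lower number here means a stronger inhibitor, a higher number a weaker inhibitor), compound 1 gives 1530 nM as a measured number. Compound 2 gives > 40000 nM in this assay and this is a limit of the assay, not a number. Compound 3 `O=C1COc2ccc(-c3cccc(NS(=O)(=O)c4ccc(F)cc4)c3)cc2N1c1ccccc1` is compound 2 with hydrogen in place of methoxy on an aromatic carbon and so 3-methoxyphenyl becomes phenyl. A small move toward stronger inhibition is expected, possibly no larger than the scatter: the estimated at least 1.6-fold lower number from compound 2 to compound 3 (0.20 log units; that floor lies within the scatter) is modest. For compound 3 the estimated value is 25000 nM (range 8000 nM to 40000 nM).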

Compound 3, half-maximal inhibitory concentration: 17700 nM
The estimate for compound 3 lay 1.4-fold (0.15 log units) above the measured number, and the stated range covers the measured number.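

In this assay, putting hydrogen in place of methoxy on the 3-methoxyphenyl group gives an at least 2.2-fold lower number from compound 2 to compound 3 (0.35 log units; beyond the scatter), the first sign that this position responds to a change. On these data alone, this is only a floor, and the true size of the step stays unknown, because compound 2 has a limit and not a number: the limit of > 40000 nM in this assay, at which 1 of the 3 values shown sits. Within this pair, the plain phenyl is the stronger inhibitor. As far as these compounds go, what a fluorine, a methyl or an amine would do at this same place remains open.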